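This account rests on a few compounds, and the source may have more. Where it says the series, first, only, none or still open, it means among the compounds named here.

Measured in a functional assay on HCT-116 cells (Homo sapiens) for inhibition; on this read-out lower numbers stand for stronger inhibition and higher numbers for weaker inhibition:
- Compound 1 `CCNC(=O)c1noc(-c2cc(C(C)C)c(O)cc2O)c1-c1cc(CO)no1`: 13 nM
- Compound 2 `CCNC(=O)c1noc(-c2cc(C(C)C)c(O)cc2O)c1-c1cc(CNC(C)C)no1`: 109 nM

Of the two, compound 2 has the higher number, which makes it the weaker inhibitor in this assay. Compound 3 `CCNC(=O)c1noc(-c2cc(C(C)C)c(O)cc2O)c1-c1cc(CNC(=O)CC)no1` differs from it at one place: propanoyl in place of isopropyl on an amine nitrogen. In words, propanoyl stands in place of isopropyl on an amine nitrogen. Among the measured compounds shown here, only one measured step bears on this change, and it concerns the same group: an 8.4-fold higher number from compound 1 to compound 2 (0.92 log units; beyond the scatter), with isopropylamino in place of hydroxy. For the measured compounds named here, no measured compound carries propanoylamino, so this is a rough guide only. Compound 3 loses the isopropylamino group, so a modest move back toward compound 1 is expected, without a full return. The step expected for compound 3 is a 2.7-fold lower number from compound 2 to compound 3 (0.44 log units; beyond the scatter). The estimated value for compound 3 is 40 nM, with an expected range of 12 nM to 130 nM.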

Compound 3, half-maximal inhibitory concentration: 78 nM
Beside the measured number, compound 3's estimate is 2.0-fold (0.29 log units) below it; the measured number falls inside the stated range.
By their numbers in this assay, from the lowest: compound 1; then compounds 3 and 2 (each within the scatter of the next).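

In this assay, the exchange of isopropyl for propanoyl on the amine nitrogen gives a 1.4-fold lower number from compound 2 to compound 3 (0.15 log units; within the scatter), so adding a carbonyl at this place leaves the read-out within the scatter. The distance from the hydroxy group of compound 1 also proves not to be unique to isopropylamino: propanoylamino gives a 6.0-fold higher number from compound 1 to compound 3 (0.78 log units; beyond the scatter), and so both nitrogen-bearing groups shown stand apart from hydroxy by more than the scatter. No measurement offered here explains either result.

The compounds shown leave open whether a primary amine or a methyl ether on the same saturated chain carbon would read closer to compound 1 or to compound 3. They also leave open whether a longer acyl chain than propanoyl would keep the read-out near that of compound 3.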